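The source may report more compounds than this note shows. Statements on the series, on what has been measured and on what is new or still open speak of the compounds shown alone.

Measured so far:
compound 1, `CCCCCCCOc1ccc(CC[C@](N)(CO)CCC)cc1`: > 10 mg/kg
compound 2, `CCCCCCCCc1ccc(CCC(N)(CO)CCO)cc1`: 0.12 mg/kg

Both compounds were tested in a functional assay on the whole organism (spleen, spleen) with Rattus norvegicus as the target; on this read-out lower numbers stand for an effect already at smaller amounts and higher numbers for an effect only at larger amounts of compound. For compound 1 the result is only a limit of the assay, > 10 mg/kg, and not a number; that this reading sits at the limit is recorded as the limit of > 10 mg/kg in this assay, at which 1 of the 2 values shown sits. For the measured compounds named here, compound 2 is thus the only compound with an actual number in this assay, where it gives 0.12 mg/kg, and no step between two measured compounds can be drawn from these two results.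

Compound 3, `CCCCCCCCc1ccc(CCC(N)(CCO)CCO)cc1`, has not yet been measured. It differs from compound 2 in one place: hydroxymethyl in place of hydroxy on a saturated chain carbon, two bonds along the chain from an amine nitrogen. Going by the values given here, no measured pair shows what such a change does in this assay. The expectation is a small to moderate loss, a step of a 3.3-fold higher number from compound 2 to compound 3 (0.52 log units; beyond the scatter) from compound 2 to compound 3, though a result within the usual scatter of repeated measurements cannot be ruled out. Compound 3 is therefore estimated at 0.4 mg/kg, with a range from 0.1 mg/kg to 2 mg/kg.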

Compound 3, dose for 50% inhibition: > 10 mg/kg
Compound 3: no number, only a limit (the forecaster's own chance of this, stated with the estimate: 10%); at least 25-fold (1.39 log units) between middle value and limit.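

Compound 2 and compound 3 differ in one place only, on a saturated chain carbon, two bonds along the chain from an amine nitrogen, where hydroxymethyl replaces hydroxy; read one bond further out, this is hydroxymethyl becoming 2-hydroxyethyl. For the compounds shown here, this is the first pair here that isolates a single change, and in this assay it gives an at least 83-fold higher number from compound 2 to compound 3 (1.92 log units; beyond the scatter), even though the count of hydrogen-bond donors and acceptors stays the same and neither group carries a net charge, so at this position a small extension of the chain can matter greatly. The reading for compound 3 is a limit of the assay and not a number, so the step marks only the least the change can amount to: the limit of > 10 mg/kg in this assay, at which 2 of the 3 values shown sit.

These compounds do not show whether the loss follows from the longer chain itself or from where its hydroxy group ends up, and a methoxymethyl or an aminomethyl group at this place would help separate the two. They also leave open whether a 3-hydroxypropyl chain here would behave like 2-hydroxyethyl, or whether the same change elsewhere on the shared core would matter as much.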